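The source may report more compounds than this note shows. Statements on the series, on what has been measured and on what is new or still open speak of the compounds shown alone.

Measured compounds in a functional assay on the whole organism (strain albino) for inhibition, with Rattus norvegicus as the target, read by paw edema, with a stated time of 3 h, at a dose of 0.28 mmol/kg by the oral route; a lower number here means less inhibition, a higher number more inhibition at the dose given (going by the name of the read-out):
compound 1, `C=CCn1c(SC/C(=N\O)c2ccccc2)nnc1-c1ccc(OC)c(OC)c1`, 58%
compound 2, `COc1ccc(-c2nnc(SC/C(=N/O)c3ccccc3)n2-c2ccccc2)cc1`, 63%
compound 3, `O/N=C(/CSc1nnc(-c2ccccc2)n1-c1ccccc1)c1ccccc1`, 65%

The three numbers lie within the usual scatter of one another, so none of the three can be set apart as giving a higher or lower number. Compound 2 stands in the middle of them, and its closest neighbour is compound 3, with the step of a number 2 percentage points higher from compound 2 to compound 3 (within the scatter), which came from hydrogen in place of methoxy on an aromatic carbon.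

Compound 4, `C=CCn1c(SC/C(=N/O)c2ccccc2)nnc1-c1ccc(OC)cc1`, has not been measured yet. It differs from compound 2 in this way: allyl in place of phenyl on an aromatic nitrogen. Among the measured compounds shown here, no measured step follows this exact exchange. For the measured compounds named here, the one measured step, from compound 2 to compound 3, touches a methoxy group on the aromatic ring and not the group on the nitrogen, so it does not speak to it. Going by the values given here, the only hint comes from compound 1, which already carries an allyl group on that nitrogen and gives 58%, a value that sits within the scatter of compound 2.

On that basis the step from compound 2 to compound 4 is expected to be a number 3 percentage points lower from compound 2 to compound 4 (within the scatter), that is, no change beyond the scatter. Compound 4 is therefore estimated at 60%, with a range from 50% to 70%.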

Compound 4, a percentage reported as inhibition, in the whole organism at one dose (the size of the read-out at that dose, not a potency): 67%
Compound 4: the middle estimate sits 7 percentage points below what was measured; measured number inside the range.
By their numbers in this assay, from the lowest: compounds 1, 2, 3 and 4 (each within the scatter of the next).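

In this assay the result is a number 4 percentage points higher from compound 2 to compound 4 (within the scatter) when phenyl on the aromatic nitrogen gives way to allyl. Among the compounds shown here, this is the first direct reading of a change at this position, and it shows that, in this pair, the six-membered aromatic ring on that nitrogen can be replaced by an open allyl chain with no shift beyond the scatter, so the two compounds cannot be told apart at this dose. Nothing measured here gives a reason for this outcome.

The compounds shown leave open how other groups on this nitrogen would read, such as a small methyl, a propyl chain without the double bond, or a longer chain ending in an amine or a carboxylic acid. Also open, going by these compounds, is whether compound 2 and compound 4 would still be indistinguishable at other doses or at other times after dosing, as a reading at a single dose gives the size of the effect and not a potency.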